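Two Limits and One Estimate for a Third Compound

The source may report more compounds than this note shows. Statements on the series, on what has been measured and on what is new or still open speak of the compounds shown alone.

Compound 1 `O=C1CN(S(=O)(=O)c2cc3ccc(Cl)cc3s2)CCN1Cc1cc2[nH]cccc-2n1` in an assay on isolated protein for binding affinity to serine protease 1 (Homo sapiens) (on this read-out higher numbers stand for weaker inhibition and lower numbers for stronger inhibition), gives > 2900 nM, a limit of the assay rather than a number.
Compound 2 `O=C1CN(S(=O)(=O)c2cc3ccc(Cl)cc3s2)CCN1Cc1cc2cnccc2o1` in this assay gives > 2900 nM, again a limit and not a number.

Compound 2 therefore stands only at a limit; its neighbour compound 1 sits at the same limit, so the step that the two limits leave unreadable from compound 1 to compound 2 cannot be read. The whole evidence is summed up in the limit of > 2900 nM in this assay, at which 2 of the 2 values shown sit, which places both values at the same limit.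

Compound 3 `O=C1CN(S(=O)(=O)c2cc3ccc(Cl)cc3s2)CCN1Cc1cc2c(O)[nH]ccc-2n1` differs from compound 2 in one place: a group of 10 heavy atoms (7 carbon, 2 nitrogen, 1 oxygen; one five-membered aromatic ring with 1 hetero atom, one six-membered aromatic ring with 1 hetero atom) in place of a group of 9 heavy atoms (7 carbon, 1 nitrogen, 1 oxygen; one five-membered aromatic ring with 1 hetero atom, one six-membered aromatic ring with 1 hetero atom), on a saturated chain carbon bound to an amide-type nitrogen in a ring. No measured step bears on this change, since the only step shown is the unreadable one from compound 1 to compound 2. With both measured compounds at a limit there is no direction to extrapolate, and the most plausible outcome for compound 3 is another limit.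

Compound 3 is estimated to give 5000 nM, within 1500 nM to 20000 nM. This estimate means a step that the limit leaves unreadable from compound 2 to compound 3, which is not expected to be readable against a limit.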

Compound 3, inhibition constant: > 2900 nM
Compound 3: no number, only a limit (the forecaster's own chance of this, stated with the estimate: 70%); the middle value lies beyond the limit too.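

For the compounds shown here, compound 3 also gives only a limit in this assay, so no step among compound 1, compound 2 and compound 3 can be read, and the evidence comes down to one shared limit: the limit of > 2900 nM in this assay, at which 3 of the 3 values shown sit. The compounds leave open how strongly each one actually inhibits the protease, and whether exchanging these groups changes that at all.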